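Aryl swap on the triazole nitrogen: compound 3

This account rests on a few compounds, and the source may have more. Where it says the series, first, only, none or still open, it means among the compounds named here.

compound 1 `N#CC1=C(N)Oc2c(N)cc3nc4ccccc4nc3c2C12C(=O)N(Cc1cnnn1-c1cccc(C(F)(F)F)c1)c1ccccc12`: 15800 nM
compound 2 `CCc1cccc(C)c1-n1nncc1CN1C(=O)C2(C(C#N)=C(N)Oc3c(N)cc4nc5ccccc5nc4c32)c2ccccc21`: > 50000 nM

In a functional assay on HepG2 cells (Homo sapiens) for antiproliferative activity, read by MTT assay, with a stated time of 48 h (a lower number here means a stronger inhibitor, a higher number a weaker inhibitor), compound 1 gives 15800 nM. For compound 2 the value > 50000 nM is a limit of the assay, not a number, so compound 2 stands at the weak end of the two values shown, at the limit of > 50000 nM in this assay, at which 1 of the 2 values shown sits. For the measured compounds named here, the only measured change at this aromatic nitrogen is an at least 3.1-fold higher number from compound 1 to compound 2 (0.50 log units; beyond the scatter). Compound 3 `COc1ccc(OC)c(-n2nncc2CN2C(=O)C3(C(C#N)=C(N)Oc4c(N)cc5nc6ccccc6nc5c43)c3ccccc32)c1` carries 2,5-dimethoxyphenyl in place of 2-ethyl-6-methylphenyl on an aromatic nitrogen. Going by the values given here, no measured step covers a dimethoxyphenyl here; starting from a limit, the step of an at least 1.2-fold lower number from compound 2 to compound 3 (0.09 log units; that floor lies within the scatter) is expected to leave the number near that limit. Compound 3 is estimated at 40000 nM (range 10000 nM to 100000 nM).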

Compound 3, half-maximal inhibitory concentration: 45100 nM
Estimate against measurement, compound 3: 1.1-fold (0.05 log units) below; measured number inside the range.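

In this assay, 2,5-dimethoxyphenyl on the aromatic nitrogen gives a 2.9-fold higher number from compound 1 to compound 3 (0.46 log units; beyond the scatter), so a second replacement of 3-(trifluoromethyl)phenyl also weakens the number, this time as a measured value. Against 2-ethyl-6-methylphenyl, the step is an at least 1.1-fold lower number from compound 2 to compound 3 (0.04 log units; that floor lies within the scatter), which fixes no order between these two groups. The value of compound 2 is a limit: the limit of > 50000 nM in this assay, at which 1 of the 3 values shown sits.

From the compounds shown here alone, whether any group on this nitrogen improves on 3-(trifluoromethyl)phenyl remains open. Also open, going by these compounds, is how a single methoxy group, a chlorine atom or a benzyl group would compare.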